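This account rests on a few compounds, and the source may have more. Where it says the series, first, only, none or still open, it means among the compounds named here.

Measured compounds:
- compound 1 `C[C@@H](O[C@@H]1CN(C(=O)C(C)(C)C)C[C@H]1c1ccccc1)c1cc(C(F)(F)F)cc(C(F)(F)F)c1`, in an assay on CHO cells for displacement of a labelled ligand from Substance-P receptor (Homo sapiens) (a higher number here means a weaker inhibitor, a lower number a stronger inhibitor), compound 1 gives 0.18 nM
- compound 2 `CC(=O)N1CCC(C(=O)N2C[C@@H](O[C@H](C)c3cc(C(F)(F)F)cc(C(F)(F)F)c3)[C@H](c3ccc(F)cc3)C2)CC1`, in this assay compound 2 gives 0.07 nM

Compound 1 has the highest number of the two in this assay, so it is the weaker of the two inhibitors. Compound 2, which differs from it in more than one place, gives a lower number, and that gap lies beyond the usual scatter of repeated measurements.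

Compound 3 `C[C@@H](O[C@@H]1CN(C(=O)N2CCOCC2)C[C@H]1c1ccccc1)c1cc(C(F)(F)F)cc(C(F)(F)F)c1` is not yet measured. It comes from compound 1 by one change at the carbonyl carbon attached to the ring nitrogen: morpholin-4-yl in place of tert-butyl on a carbonyl carbon. Among the compounds with values here, no single-point step between measured compounds is known here, so the expectation rests on compound 1 alone. Compound 2 shows that a different group on the same carbonyl is compatible with strong binding, but its other changes prevent a direct reading. A modest step, within or near the scatter, is expected, leaning slightly toward a higher number, and the estimated step is a 1.7-fold higher number from compound 1 to compound 3 (0.22 log units; within the scatter). For compound 3 in this assay the estimate is 0.3 nM, expected to fall between 0.08 nM and 1.2 nM.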

Compound 3, half-maximal inhibitory concentration: 0.16 nM
For compound 3 the middle estimate is 1.9-fold (0.27 log units) above the measured one; the range from low to high includes it.
By their numbers in this assay, from the lowest: compound 2; then compounds 3 and 1 (each within the scatter of the next).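

In this assay, morpholin-4-yl in place of tert-butyl on the carbonyl carbon gives a 1.1-fold lower number from compound 1 to compound 3 (0.05 log units; within the scatter) and this step lies within the scatter, so the two compounds cannot be told apart. Within the data shown here, this gives the first direct reading at this position: a group of 6 heavy atoms with a six-membered ring and a hydrogen-bond acceptor stands in for a group of 4 heavy atoms with neither, and binding stays in the same range, which compound 2 could not show on its own since it differs from compound 1 in more than one place. No measurement at hand explains why the two groups read alike.

The compounds shown leave open whether this carbonyl carbon also accepts a group with a free amine, such as piperazin-1-yl, or one bearing a carboxylic acid, since neither the tert-butyl nor the morpholin-4-yl has a hydrogen-bond donor or a net charge. They also leave open whether the same exchange would read alike on a core with a fluorine on the phenyl ring, as in compound 2.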